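The compounds below may be only part of what the source reports. "The series", "measured", "known", "first", "only" and "open" are said of these compounds alone.

Of the compounds shown here, three that share one core have been measured in an assay on mitochondria from L6 cells (Rattus norvegicus) for activation, with a stated time of 90 min; on this read-out higher numbers stand for an effect only at larger amounts of compound and lower numbers for an effect already at smaller amounts. Compound 1 `Oc1nc2nonc2nc1Nc1ccc(S(F)(F)(F)(F)F)cc1` gives 3900 nM, compound 2 `Oc1nc2nonc2nc1Nc1ccccc1` gives 66700 nM, and compound 3 `CC(C)(C)c1ccc(Nc2nc3nonc3nc2O)cc1` gives 3900 nM. Compound 3 thus stands level with compound 1, the two together giving the lowest numbers of the three, while compound 2 sits far from both: a 17-fold lower number from compound 2 to compound 3 (1.23 log units; beyond the scatter). Between compound 1 and compound 3 the step is no change at the digits printed from compound 1 to compound 3 (within the scatter).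

Compound 4 `CC(=O)c1ccc(Nc2nc3nonc3nc2O)cc1` has not yet been measured in this assay. It differs from compound 3 in one place: acetyl in place of tert-butyl on an aromatic carbon. The measured step that bears most directly on this change is a 17-fold lower number from compound 2 to compound 3 (1.23 log units; beyond the scatter), in which tert-butyl entered in place of hydrogen on an aromatic carbon; the step of no change at the digits printed from compound 1 to compound 3 (within the scatter) adds that a group of 6 heavy atoms and a group of 4 heavy atoms at that aromatic carbon gave the same number. Acetyl is neither hydrogen nor a group of that kind, so the expectation for compound 4 is a rise smaller than the one seen when the group was absent altogether, with the estimated step being a 2.6-fold higher number from compound 3 to compound 4 (0.41 log units; beyond the scatter). Compound 4 is therefore expected to give about 10000 nM, within a range from 3000 nM to 40000 nM.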

Compound 4, half-maximal effective concentration: 93700 nM
For compound 4 the middle estimate is 9.4-fold (0.97 log units) below the measured one; measured number outside the range, above it.
By their numbers in this assay, from the lowest: compounds 1 and 3 (each within the scatter of the next); then compounds 2 and 4 (each within the scatter of the next).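

In this assay, this aromatic carbon no longer looks like a place where any added group lowers the number: the step to acetyl reads a 1.4-fold higher number from compound 2 to compound 4 (0.15 log units; within the scatter), so compound 4 cannot be told apart from the compound bearing only hydrogen. Exchanging tert-butyl for acetyl gives a 24-fold higher number from compound 3 to compound 4 (1.38 log units; beyond the scatter), and exchanging the group of 6 heavy atoms for acetyl gives a 24-fold higher number from compound 1 to compound 4 (1.38 log units; beyond the scatter), so the two groups that had matched each other now both separate clearly from acetyl. Filling this position is therefore not enough on its own, and what matters is which group sits there, at least among the four shown.

Acetyl differs from tert-butyl in its carbonyl, its hydrogen-bond acceptor and its heavy-atom count, and these compounds cannot separate those differences; an isopropyl group at the same carbon, or an amine or a carboxylic acid, would help to do so. It also remains open why acetyl behaves like hydrogen here, and no independent measurement bears on that question.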